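The compounds below may be only part of what the source reports. "The series", "measured", "known", "first", "only" and "open" are said of these compounds alone.

Measured compounds:
compound 1 `N#Cc1ccc(NC(=O)c2ccc(-c3ncccc3C(F)(F)F)cc2)cc1` — 417 nM
compound 2 `CC(C)(C)c1ccc(NC(=O)c2ccc(-c3ncccc3C#N)cc2)cc1` — 30 nM

Two compounds have numbers in a functional assay for antagonist activity at transient receptor potential cation channel subfamily V member 1 (Homo sapiens), read by FLIPR; a lower number here means a stronger inhibitor, a higher number a weaker inhibitor. Compound 1 `N#Cc1ccc(NC(=O)c2ccc(-c3ncccc3C(F)(F)F)cc2)cc1` gives 417 nM in this assay. Compound 2 `CC(C)(C)c1ccc(NC(=O)c2ccc(-c3ncccc3C#N)cc2)cc1` gives 30 nM in this assay, the lower of the two numbers, and the gap between compound 1 and compound 2 lies beyond the scatter. Among the compounds with values here, these two compounds differ from each other in more than one place, so no single step between them can be traced.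

Compound 3 `CC(C)(C)c1ccc(NC(=O)c2ccc(-c3ncccc3C(=N)N)cc2)cc1` has not yet been measured. It differs from compound 2 in one place: a group of 3 heavy atoms (1 carbon, 2 nitrogen; no ring) in place of a group of 2 heavy atoms (1 carbon, 1 nitrogen; no ring), on an aromatic carbon. Within the data shown here, no measured pair shows this change, so its effect is not known from the data at hand. On the counted change alone, compound 3 is expected to give a higher number than compound 2, with the step from compound 2 to compound 3 estimated at a 10-fold higher number from compound 2 to compound 3 (1.00 log units; beyond the scatter), while a step within the scatter cannot be ruled out. Compound 3 is therefore expected to give 300 nM in this assay, with a range from 60 nM to 1500 nM.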

Compound 3, half-maximal inhibitory concentration: > 4000 nM
Compound 3 gave a limit, no number; the forecaster's own chance of this, stated with the estimate: 10%; at least 13-fold (1.12 log units) between middle value and limit.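

On the aromatic carbon two atoms from the ring nitrogen, replacing cyano with the group of 3 heavy atoms, which carries 2 hydrogen-bond donors, gives an at least 130-fold higher number from compound 2 to compound 3 (2.12 log units; beyond the scatter) in this assay, so this position does not accept every small group alike. The earlier pair could not show this: compound 1 and compound 2 differ in more than one place, whereas this is a single traced change, and its step lies beyond the scatter. The result for compound 3 is a limit of the assay and not a number: the limit of > 4000 nM in this assay, at which 1 of the 3 values shown sits.

The compounds shown do not separate the hydrogen-bond donors of the entering group from its other features, and an aminomethyl group, a primary carboxamide or a methyl ester on the same carbon would be needed to tell these apart. Within the data shown here, they also leave open how the trifluoromethyl group of compound 1 compares with cyano on this carbon when the rest of the molecule stays the same, and the data here give no single step for that change.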